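The source may hold more compounds than are shown below. What is called first, only, known or untested is meant among the compounds shown, and "the series" means these compounds.

Among the compounds with values here, compound 2 `O=C(Nc1ccc(Cl)c(-c2nnc3c(Cl)cccn23)c1)c1ccccc1` carries a plain benzoyl group on the amide nitrogen and, in a functional assay on MDA-MB-231 cells (Homo sapiens) for antiproliferative activity, read by MTT assay, with stated times of 72 h and 4 h (a higher number here means a weaker inhibitor, a lower number a stronger inhibitor), compound 2 gives 58200 nM, the only real number in this small set. Compound 1 `Cc1cc(Cl)ccc1C(=O)Nc1ccc(Cl)c(-c2nnc3c(Cl)cccn23)c1` differs only in that acyl part and in this assay compound 1 gives > 100000 nM, which is a limit of the assay rather than a number (the limit of > 100000 nM in this assay, at which 1 of the 2 values shown sits). Within the data shown here, the single measured step, an at least 1.7-fold lower number from compound 1 to compound 2 (0.23 log units; that floor lies within the scatter), is all the guidance available. Compound 3 `O=C(Nc1ccc(Cl)c(-c2nnc3c(Cl)cccn23)c1)c1ccccc1Cl` is the next variation: chloro in place of hydrogen on an aromatic carbon, ortho to a large group. This change walks part of the way back from compound 2 toward compound 1, and because an at least 1.7-fold lower number from compound 1 to compound 2 (0.23 log units; that floor lies within the scatter) had a floor that may be small, compound 3 is expected to give a somewhat higher number, a 1.5-fold higher number from compound 2 to compound 3 (0.19 log units; within the scatter), with a real chance that only a limit is reported. The estimate for compound 3 is 90000 nM, within 40000 nM to 200000 nM.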

Compound 3, half-maximal inhibitory concentration: 59900 nM
Compound 3: the middle estimate sits 1.5-fold (0.18 log units) above what was measured; the range from low to high includes it.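

Compound 3 adds the first direct test of this ring position: chloro in place of hydrogen on an aromatic carbon, ortho to a large group, gives a 1.0-fold higher number from compound 2 to compound 3 (0.01 log units; within the scatter), so this assay does not tell these two compounds apart. The other new comparison, an at least 1.6-fold lower number from compound 1 to compound 3 (0.22 log units; that floor lies within the scatter), offers only a floor and does not establish a real difference. Compound 1 gives a limit of the assay and not a number: the limit of > 100000 nM in this assay, at which 1 of the 3 values shown sits.

From the compounds shown here alone, it remains open whether an amine or a carboxylic acid in place of this chloro would give a step beyond the scatter. The compounds shown also do not separate the contributions of the methyl and the chloro within the 4-chloro-2-methylphenyl group of compound 1.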